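This account rests on a few compounds, and the source may have more. Where it says the series, first, only, none or still open, it means among the compounds named here.

Compound 1 (`Nc1nc(NCCNc2ncc(-c3ncc[nH]3)c(-c3ccc(Cl)cc3)n2)ccc1[N+](=O)[O-]`), compound 2 (`Nc1nc(NCCNc2ncc(-c3ncc[nH]3)c(-c3cc(F)c(F)cc3F)n2)ccc1[N+](=O)[O-]`) and compound 3 (`Nc1nc(NCCNc2ncc(-c3ncc[nH]3)c(-c3ccc(F)cc3C(F)(F)F)n2)ccc1[N+](=O)[O-]`) share a core and differ only in one substituted phenyl group. All three have been tested in an ADME assay on microsomes from liver (Canis lupus familiaris) for metabolic stability; on this read-out higher numbers stand for a longer-lived compound and lower numbers for a shorter-lived compound. Compound 1 gives > 0.5 h, which is a limit of the assay and not a number. Compound 2 gives > 0.5 h, which is also a limit. Compound 3, the starting point here, gives > 0.5 h, again a limit and not a number.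

Compound 4 (`Nc1nc(NCCNc2ncc(-c3ncc[nH]3)c(-c3ccc(Cl)cc3Br)n2)ccc1[N+](=O)[O-]`) has not yet been measured. It differs from compound 3 at one place: 2-bromo-4-chlorophenyl in place of 4-fluoro-2-(trifluoromethyl)phenyl on an aromatic carbon. In words, 2-bromo-4-chlorophenyl stands in place of 4-fluoro-2-(trifluoromethyl)phenyl on an aromatic carbon, ortho to a 1H-imidazol-2-yl group.

Three measured changes of this same group bear on the new one. They are a step that the two limits leave unreadable from compound 1 to compound 2, a step that the two limits leave unreadable from compound 1 to compound 3 and a step that the two limits leave unreadable from compound 2 to compound 3. None of them has a readable size, and the whole set sits at the limit of > 0.5 h in this assay, at which 3 of the 3 values shown sit. No step beyond the usual scatter is therefore expected, and compound 4 will probably be reported as a limit too. The expected outcome is a step that the limit leaves unreadable from compound 3 to compound 4. For compound 4 the estimated half-life is 0.7 h, with an expected range from 0.4 h to 1.5 h.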

Compound 4, half-life: > 0.5 h
Compound 4: no number, only a limit (the forecaster's own chance of this, stated with the estimate: 85%); the middle value is on the limit's open side.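

Compound 4, like compound 1, compound 2 and compound 3, gives only a limit and not a number in this assay, so no step between any of them can be read: the limit of > 0.5 h in this assay, at which 4 of the 4 values shown sit.

The compounds shown leave open what the actual half-life of each one is, and whether changing the substituted phenyl group shifts it at all.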